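The source may report more compounds than this note shows. Statements on the series, on what has been measured and on what is new or still open speak of the compounds shown alone.

Of the compounds shown here, two have been measured in a functional assay on the whole organism (blood) with Rattus norvegicus as the target, with stated times of 24 h and 1 h, at a dose of 5 mg/kg by the intraperitoneal route; on this read-out lower numbers stand for a weaker effect and higher numbers for a stronger effect at the one dose given. Compound 1 `COc1ccc(Cl)cc1C(=O)NCC1CCN(S(=O)(=O)NC(=O)NC2CCCCC2)CC1` gives 20% in this assay. Compound 2 `O=C(NC1CCCCC1)NS(=O)(=O)N1CCC(CCNC(=O)c2csnn2)CC1` gives 19% in this assay. Of the two numbers, compound 2 holds the smaller one, yet compound 1 lies so close that the gap is within the usual scatter of repeated measurements, and the two results cannot be told apart.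

Compound 3 `O=C(NC1CCCCC1)NS(=O)(=O)N1CCC(CCNC(=O)c2cccc3c2OCCO3)CC1` has not yet been tested. It differs from compound 2 in a single place: 2,3-dihydro-1,4-benzodioxin-5-yl in place of 1,2,3-thiadiazol-4-yl on a carbonyl carbon. Going by the values given here, no pair of measured compounds shows a step of this kind, so nothing here sets a size or a direction for it. The step in this assay is therefore expected to be a number 3 percentage points higher from compound 2 to compound 3 (within the scatter), which amounts to no change beyond the scatter. Compound 3 is expected to give about 22% in this assay, with a range from 8% to 40%.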

Compound 3, a percentage reported as activity, at one dose (the size of the read-out at that dose, not a potency): 34%
The estimate for compound 3 lay 12 percentage points below the measured number, and the stated range covers the measured number.
By their numbers in this assay, from the lowest: compounds 2 and 1 (each within the scatter of the next); then compound 3.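

In this assay, going by these compounds alone, the swap of 1,2,3-thiadiazol-4-yl for 2,3-dihydro-1,4-benzodioxin-5-yl on the carbonyl carbon brings a number 15 percentage points higher from compound 2 to compound 3 (beyond the scatter) and so gives the first sign that the group at this position can move the read-out. The earlier compounds shown here offered no step of this kind, so they could not show this. The swap changes the ring system, the heavy-atom count and the hetero atoms all at once, and nothing available explains the rise.

On these data alone, it remains open whether the benzene ring alone would give the same result as the full 2,3-dihydro-1,4-benzodioxin-5-yl group, which a plain phenyl group on the same carbonyl carbon could test. A pyridine ring or a phenyl group carrying an amine in this place also remains an open case.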